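Adding 4-methoxyphenyl to compound 2

This account rests on a few compounds, and the source may have more. Where it says the series, first, only, none or still open, it means among the compounds named here.

In a functional assay on PC-3 cells (Homo sapiens) for cytotoxicity, read by WST assay, with a stated time of 48 h (on this read-out lower numbers stand for stronger inhibition and higher numbers for weaker inhibition), compound 1 (`COc1ccc2[nH]cc(/C=C(\C#N)C(=O)c3c[nH]c4ccccc34)c2c1`) gives 30500 nM. Compound 2 (`N#C/C(=C\c1c[nH]c2ccccc12)C(=O)c1c[nH]c2ccccc12`) reads > 50000 nM, which is a limit of the assay and not a number. Compound 3 (`COc1ccc(-c2[nH]c3ccccc3c2/C=C(\C#N)C(=O)c2c[nH]c3ccccc23)cc1`) has 4-methoxyphenyl in place of hydrogen on an aromatic carbon next to the ring nitrogen: 4-methoxyphenyl in place of hydrogen on an aromatic carbon. Among the compounds with values here, the one measured step, an at least 1.6-fold higher number from compound 1 to compound 2 (0.21 log units; that floor lies within the scatter), is a different change, hydrogen in place of methoxy, and offers only weak guidance. A modest move to lower numbers is expected in this assay, as an at least 2.0-fold lower number from compound 2 to compound 3 (0.30 log units; that floor lies within the scatter). The estimate for compound 3 is 25000 nM, with an expected range of 8000 nM to 50000 nM.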

Compound 3, half-maximal inhibitory concentration: 8100 nM
Estimate against measurement, compound 3: 3.1-fold (0.49 log units) above; low and high end bracket the measured number.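

In this assay, 4-methoxyphenyl on the aromatic carbon next to the ring nitrogen gives an at least 6.1-fold lower number from compound 2 to compound 3 (0.79 log units; beyond the scatter). Unlike the earlier methoxy change, whose floor lies within the scatter, this change at a new position has a step beyond the scatter, so this carbon accepts a large aromatic group without loss of activity. The step is a floor and not a full size: the limit of > 50000 nM in this assay, at which 1 of the 3 values shown sits.

Open, on these data alone, is whether the step belongs to the six-membered ring or to its methoxy. A plain phenyl, or a phenyl bearing an amine or a carboxylic acid, would separate these.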